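Vinyl in Place of Methyl on a Cyclopropane-Spiro Core

This account rests on a few compounds, and the source may have more. Where it says the series, first, only, none or still open, it means among the compounds named here.

Measured so far:
compound 1, `C/C=C1\C=C(C)C2(CC2)C(C)(O)C1=O`: 150 nM
compound 2, `CC1=C/C(=C\C#CCCO)C(=O)C(C)(O)C12CC2`: 3000 nM

The two measured compounds were tested in a functional assay on A549 cells (Homo sapiens) for antiproliferative activity; on this read-out higher numbers stand for weaker inhibition and lower numbers for stronger inhibition. Compound 1 gives 150 nM, the lowest of the two numbers, so it is the stronger inhibitor of the pair. Compound 2, in which a 4-hydroxybut-1-yn-1-yl group replaces the methyl on a double-bonded chain carbon bound to a double-bonded ring carbon, gives 3000 nM; that step, a 20-fold higher number from compound 1 to compound 2 (1.30 log units; beyond the scatter), is far beyond the scatter.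

Compound 3, `C=C/C=C1\C=C(C)C2(CC2)C(C)(O)C1=O`, has not yet been measured. It differs from compound 1 by vinyl in place of methyl on a double-bonded chain carbon bound to a double-bonded ring carbon. Within the data shown here, the only measured step at this position is a 20-fold higher number from compound 1 to compound 2 (1.30 log units; beyond the scatter), which shows that a long chain carrying a hydroxyl weakens activity strongly. Vinyl is a much smaller change with no hydroxyl, so a milder effect is expected, possibly none beyond the scatter, though a weakening in the same direction cannot be ruled out. The expected step is a 1.7-fold higher number from compound 1 to compound 3 (0.22 log units; within the scatter). Compound 3 is therefore estimated at 250 nM, within a range of 80 nM to 800 nM.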

Compound 3, half-maximal inhibitory concentration: 2 nM
Compound 3: the middle estimate sits 130-fold (2.10 log units) above what was measured; the measured number lies below the stated range.
By their numbers in this assay, from the lowest: compound 3; then compound 1; then compound 2.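

In this assay, the place on a double-bonded chain carbon bound to a double-bonded ring carbon can move the number in both directions: the earlier step showed only a rise, whereas vinyl in place of methyl gives a 75-fold lower number from compound 1 to compound 3 (1.88 log units; beyond the scatter). Vinyl in place of 4-hydroxybut-1-yn-1-yl at the same place gives a 1500-fold lower number from compound 2 to compound 3 (3.18 log units; beyond the scatter), so on an unchanged core this one group spans a very wide range, and a small change here can matter as much as a large one. Nothing available explains why vinyl differs so sharply from methyl.

The compounds shown leave open whether the double bond of vinyl matters or whether a saturated group such as ethyl would read the same at this place. They also leave open how a longer chain such as buta-1,3-dien-1-yl would read, and whether the hydroxyl or the triple bond of 4-hydroxybut-1-yn-1-yl goes with the higher number of compound 2.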